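Methylamino in place of methoxy on a shared core

A few compounds are considered here, and "the series" means these few. Any claim that something is new, unique, unknown or untested is made for them only; others in the source may bear on it.

Compound 1 `CCCCCCCC(CCO)n1cnc2c(NC)ncnc21` gives 12500 nM
Compound 2 `CCCCCCCCCCC(CCO)n1cnc2c(OC)ncnc21` gives 7530 nM

Among the measured compounds shown here, in a functional assay on HCT-116 cells (Homo sapiens) for antiproliferative activity, read by MTT assay, with a stated time of 48 h (on this read-out higher numbers stand for weaker inhibition and lower numbers for stronger inhibition), compound 2 stands at 7530 nM and compound 1 at 12500 nM on the only two numbers so far. These lie within the usual scatter of each other, so neither can be ranked above the other. Compound 3 (`CCCCCCCCCCC(CCO)n1cnc2c(NC)ncnc21`) is compound 2 with one change: methylamino in place of methoxy on an aromatic carbon. For the measured compounds named here, no measured pair shows this swap alone. Compound 1 already carries methylamino on a different chain, and at 12500 nM it gives no sign of a large effect. The expected change in this assay, a 1.1-fold lower number from compound 2 to compound 3 (0.03 log units; within the scatter), is therefore estimated to stay within the scatter, in neither direction clearly. For compound 3 the estimated value is 7000 nM, with an expected range from 3500 nM to 14000 nM in this test.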

Compound 3, half-maximal inhibitory concentration: 12700 nM
Compound 3: middle estimate off by 1.8-fold (0.26 log units), on the low side, within the range that was stated.
By their numbers in this assay, from the lowest: compounds 2, 1 and 3 (each within the scatter of the next).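

In this assay the swap of methylamino in place of methoxy on an aromatic carbon can now be read directly on one shared core, and it gives a 1.7-fold higher number from compound 2 to compound 3 (0.23 log units; within the scatter) so the two groups cannot be told apart at this position. Propyl in place of hydrogen on a saturated chain carbon, eight bonds along the chain from an aromatic nitrogen, gives a 1.0-fold higher number from compound 1 to compound 3 (0.01 log units; within the scatter) so with methylamino in place this difference in chain length also leaves no readable separation. Nothing measured here bears on why these numbers stay so close.

Still open, as far as these compounds go, is whether a different group on this aromatic carbon, such as a dimethylamino group or a chlorine atom, would move the number beyond the scatter. Also open, from the compounds shown here alone, is what a much shorter chain, or a carboxylic acid on the chain, would do.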